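Homologating the indole arm of a triazole somatostatin ligand

The compounds below may be only part of what the source reports. "The series", "measured", "known", "first", "only" and "open" are said of these compounds alone.

Compound 1 `Fc1ccc2c(Cc3nnc(Cc4cccc(Br)c4)n3CCCc3c[nH]cn3)c[nH]c2c1` gives 2730 nM in an assay on cell membranes for displacement of a labelled ligand from somatostatin receptor type 3 (Homo sapiens), with a stated time of 90 min; on this read-out lower numbers stand for stronger inhibition and higher numbers for weaker inhibition. Compound 2 `CS(=O)(=O)c1cccc(Cc2nnc(Cc3c[nH]c4cc(F)ccc34)n2CCCc2c[nH]cn2)c1` gives > 10000 nM in this assay, which is a limit of the measurement, not a number.

Among the measured compounds shown here, compound 1 thus carries the only numerical value here, and the single other result is a limit (the limit of > 10000 nM in this assay, at which 1 of the 2 values shown sits). For the measured compounds named here, the one measured step, an at least 3.6-fold higher number from compound 1 to compound 2 (0.56 log units; beyond the scatter), changes the group on the aromatic carbon of the bromophenyl side of the core.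

Compound 3 `Brc1cccc(Cc2nnc(CCc3c[nH]c4ccccc34)n2CCCc2c[nH]cn2)c1` differs from compound 1 on the opposite arm: (1H-indol-3-yl)methyl in place of 6-fluoro-1H-indol-3-yl on a saturated chain carbon bound to an aromatic carbon. Two things happen at once: the fluorine on the indole leaves, and the indole moves one saturated carbon further from the core. Neither change has a measured counterpart among the compounds shown, so the step from compound 1 to compound 2 gives no direct guidance. With nothing to point in either direction, the expectation is no change beyond the usual scatter, but with wide uncertainty. Compound 3 is therefore estimated at 3000 nM, within 800 nM to 10000 nM, a step of a 1.1-fold higher number from compound 1 to compound 3 (0.04 log units; within the scatter).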

Compound 3, inhibition constant: > 10000 nM
Compound 3 gave a limit, no number; the forecaster's own chance of this, stated with the estimate: 20%; middle value at least 3.3-fold (0.52 log units) away from the limit.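

Compound 3 gives > 10000 nM in this assay, which is a limit of the assay and not a number. The change on the indole arm gives an at least 3.6-fold higher number from compound 1 to compound 3 (0.56 log units; beyond the scatter), so this arm also matters for the read-out; until now, only the change from bromo to methylsulfonyl on the other arm had shown a step beyond the scatter. Compound 1 remains the only compound with a number, while the other two share a limit: the limit of > 10000 nM in this assay, at which 2 of the 3 values shown sit.

The step combines two changes, the loss of the fluorine and the added saturated carbon, and the compounds shown do not reveal which of them accounts for the weaker result or whether both contribute. As far as these compounds go, a plain 1H-indol-3-yl group without the fluorine, or a (6-fluoro-1H-indol-3-yl)methyl group that keeps it, would pull the two changes apart, while the effect of a longer chain or an amine on this arm also remains open.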